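The source may hold more compounds than are shown below. What is called first, only, known or untested is meant among the compounds shown, and "the series" means these compounds.

In a functional assay on U-87MG ATCC cells for cytotoxicity against U-87 MG (Homo sapiens), read by colorimetric assay and MTT assay (on this read-out higher numbers stand for weaker inhibition and lower numbers for stronger inhibition), the measured compounds read as follows:

- compound 1 `COc1ccc(-c2cc3c(OC)cc(OC)cc3n(CCCC#N)c2=O)cc1` gives 10000 nM
- compound 2 `COc1ccc(-c2cc3c(OC)cc(OC)cc3n(CC(=O)O)c2=O)cc1` gives 10000 nM
- compound 3 `COC(=O)CCn1c(=O)c(-c2ccc(OC)cc2)cc2c(OC)cc(OC)cc21` gives 10000 nM

Compound 3 gives 10000 nM and so stands level with compound 1 and compound 2 on these numbers. The next compound, compound 4 `COc1ccc(-c2cc3c(OC)cc(OC)cc3n(CCC(=O)OCc3ccccc3)c2=O)cc1`, changes methoxycarbonyl to benzyloxycarbonyl, which is phenyl in place of hydrogen on a saturated chain carbon bound to an oxygen next to a carbonyl group in that group. For the measured compounds named here, three measured steps bear on this, all at the end of the same chain: no change at the digits printed from compound 1 to compound 2 (within the scatter) is the first, no change at the digits printed from compound 1 to compound 3 (within the scatter) the second and no change at the digits printed from compound 2 to compound 3 (within the scatter) the third. None of the three had any measurable size, but none of them adds a phenyl, so they offer only indirect guidance. Going by the values given here, nothing measured so far has moved this assay from this level, and the data favour no direction. The expected outcome is no change at the digits printed from compound 3 to compound 4 (within the scatter) with no shift beyond the scatter. For compound 4 the estimated value is 10000 nM with a range from 4000 nM to 20000 nM expected.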

Compound 4, half-maximal inhibitory concentration: 10000 nM
Compound 4: the middle estimate sits on the measured number at the digits printed, and the stated range covers the measured number.
By their numbers in this assay, from the lowest: compounds 1, 2, 3 and 4 (each within the scatter of the next).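

In this assay, for the compounds shown here, phenyl in place of hydrogen on a saturated chain carbon bound to an oxygen next to a carbonyl group gives no change at the digits printed from compound 3 to compound 4 (within the scatter), so this is the first direct reading of an aromatic ring added at this place, and it does not move the read-out. The benzyloxycarbonyl end also reads level with the other chain ends, with no change at the digits printed from compound 2 to compound 4 (within the scatter) and no change at the digits printed from compound 1 to compound 4 (within the scatter), so the flat picture now holds across all four groups shown. Nothing available explains why this change leaves the reading as it stands.

From the compounds shown here alone, it remains open whether an amine or a primary amide at the end of this chain, or a longer chain, would shift the reading at all. Going by these compounds, it is equally open whether replacing a methoxy group on the shared core with a hydroxyl would do so.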